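Configuration step from compound 2 to compound 3

The source may hold more compounds than are shown below. What is called first, only, known or untested is meant among the compounds shown, and "the series" means these compounds.

Measured so far in an ADME assay (Mus musculus, strain C57BL/6) for metabolic stability, read by HPLC, with a stated time of 12 h; a lower number here means that the compound disappears faster, a higher number that the compound lasts longer:
- compound 1 `O=C(O)[C@@H](CO)NC(=O)[C@H]1C[C@H](O)CN1`: > 12 h (a limit)
- compound 2 `O=C(O)[C@H](CO)NC(=O)[C@H]1C[C@@H](O)CN1`: > 12 h (a limit)

On the numbers available, compound 2 has no exact half-life. In this assay compound 2 gives > 12 h, which is a limit and not a number. Compound 3 `O=C(O)[C@H](CO)NC(=O)[C@@H]1C[C@@H](O)CN1` is reached from compound 2 through (the two compounds have the same atoms and bonds and differ only in configuration as drawn: 1 of 3 stereo elements differ; a stereocentre at a saturated ring carbon is drawn R in compound 2 and S in compound 3). Nothing leaves and nothing enters.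

For the measured compounds named here, the one measured step that bears on this change is a step that the two limits leave unreadable from compound 1 to compound 2. Its relevance lies in the fact that compounds 1 and 2 differ only in the configuration as drawn. On these data alone, its size stays unknown, with the limit of > 12 h in this assay, at which 2 of the 2 values shown sit. No step beyond the scatter is therefore expected, and no direction can be assigned. Another limit is the likely report.

For compound 3 the expected half-life is 14 h, with an estimated range of 8 h to 24 h. The expected change is a step that the limit leaves unreadable from compound 2 to compound 3.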

Compound 3, half-life: 0.86 h
The estimate for compound 3 lay 16-fold (1.21 log units) above the measured number, and the stated range ends above it.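

In this assay, for the compounds shown here, inverting a single stereocentre at a saturated ring carbon gives an at least 13-fold lower number from compound 2 to compound 3 (1.14 log units; beyond the scatter), the first step that can be read. Nothing leaves or enters at this position, so the change rests on configuration alone: the fact that compounds 2 and 3 differ only in the configuration as drawn

Inverting all stereocentres gives a step of the same printed size, an at least 13-fold lower number from compound 1 to compound 3 (1.14 log units; beyond the scatter), whereas the step between the two earlier compounds cannot be read, so those compounds gave no sign that configuration could matter here.

On these data alone, the full size of both new steps stays open, since each starts from a limit and not a number. Also open, as far as these compounds go, is whether this ring stereocentre has a comparable effect in this assay when a methyl ester replaces the carboxylic acid.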